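A few compounds are considered here, and "the series" means these few. Any claim that something is new, unique, unknown or untested is made for them only; others in the source may bear on it.

Three compounds share one core, and one of them has no number yet. Compound 1 `COc1ccc(/C=C\C(=O)O)c(OCc2cn(-c3ccc(NC(C)=O)cc3)nn2)c1CC=C(C)C` has no result in a functional assay on HCT-116 cells (Homo sapiens) for cytotoxicity, read by MTT assay, with a stated time of 24 h (a lower number here means a stronger inhibitor, a higher number a weaker inhibitor), so far: in this assay compound 1 gives "not determined" (no result reported). Compound 2 `COc1ccc(-n2cc(COc3c(/C=C\C(=O)O)ccc(OC)c3CC=C(C)C)nn2)cc1` gives 8700 nM, the lower of the two numbers that exist. Compound 3 `COc1ccc(/C=C\C(=O)O)c(OCc2cn(-c3ccccc3C(=O)N3CCC(O)C3)nn2)c1CC=C(C)C` gives 32000 nM, a higher number than compound 2, and that gap lies beyond the usual scatter, so compound 2 is the stronger inhibitor of the two.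

Compound 4 `COc1ccc(/C=C\C(=O)O)c(OCc2cn(-c3cccc([N+](=O)[O-])c3)nn2)c1CC=C(C)C` is the compound to be measured. It differs from compound 2 in one place: 3-nitrophenyl in place of 4-methoxyphenyl on an aromatic nitrogen. Going by the values given here, no pair of measured compounds shows this kind of exchange, so no measured step guides it. With only the change of one ring substituent on the same framework, the expected step from compound 2 to compound 4 is a 1.1-fold lower number from compound 2 to compound 4 (0.04 log units; within the scatter), an estimate of no change beyond the scatter rather than a clear gain or loss. On that basis compound 4 is estimated at 8000 nM, with an expected range from 3000 nM to 25000 nM.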

Compound 4, half-maximal inhibitory concentration: 27300 nM
For compound 4 the middle estimate is 3.4-fold (0.53 log units) below the measured one; measured number above the stated range.
By their numbers in this assay, from the lowest: compound 2; then compounds 4 and 3 (each within the scatter of the next).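

In this assay, putting 3-nitrophenyl in place of 4-methoxyphenyl on an aromatic nitrogen of the five-membered ring gives a 3.1-fold higher number from compound 2 to compound 4 (0.50 log units; beyond the scatter) and so a modest loss. Going by these compounds alone, this is the first step between two measured compounds that differ in one place, and it shows that the number responds to the group carried on this nitrogen. The data at hand offer no measurement that explains this step.

The exchange alters both the ring substituent and where it sits, so the compounds shown cannot tell which of the two matters. A 4-nitrophenyl or a 3-methoxyphenyl group would separate these two changes, while an unsubstituted phenyl or an aminophenyl group would show how the number moves with other groups at this nitrogen.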